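Trimming a methyl from a hydroxyalkyl amine side chain

A few compounds are considered here, and "the series" means these few. Any claim that something is new, unique, unknown or untested is made for them only; others in the source may bear on it.

Compound 2 `CC(C)Nc1ccc(NC(=O)c2cc(Cl)ccc2O)c(Cl)c1` and compound 1 `CCNc1ccc(NC(=O)c2cc(Cl)ccc2O)c(Cl)c1` share one core and differ only by hydrogen in place of methyl on a saturated chain carbon bound to a nitrogen on an aromatic ring and a saturated chain carbon. In an ADME assay on A549 cells (Homo sapiens) for cytotoxicity, read by resazurin assay, with a stated time of 48 h (on this read-out lower numbers stand for higher toxicity in this test and higher numbers for lower toxicity in this test), compound 2 gives 11000 nM, while compound 1 gives 30200 nM; this is a 2.7-fold higher number from compound 2 to compound 1 (0.44 log units; beyond the scatter). Compound 3 `CC(C)(CCO)Nc1ccc(NC(=O)c2cc(Cl)ccc2O)c(Cl)c1` carries a longer side chain and differs from compound 2 by 2-hydroxyethyl in place of hydrogen on a saturated chain carbon bound to a nitrogen on an aromatic ring and two saturated chain carbons. In this assay compound 3 gives 170000 nM, which is a 15-fold higher number from compound 2 to compound 3 (1.19 log units; beyond the scatter) and a 5.6-fold higher number from compound 1 to compound 3 (0.75 log units; beyond the scatter).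

Compound 4 `CC(CCO)Nc1ccc(NC(=O)c2cc(Cl)ccc2O)c(Cl)c1` has not yet been measured. It differs from compound 3 by hydrogen in place of methyl on a saturated chain carbon bound to a nitrogen on an aromatic ring and two saturated chain carbons. Going by the values given here, this is the same kind of change as the one from compound 2 to compound 1, but not the same place: there the carbon is bound to a nitrogen on an aromatic ring and a saturated chain carbon, here to a nitrogen on an aromatic ring and two saturated chain carbons. In this assay the expected step is a 1.6-fold higher number from compound 3 to compound 4 (0.22 log units; within the scatter), set beside the measured 2.7-fold higher number from compound 2 to compound 1 (0.44 log units; beyond the scatter) and resting on compound 3 already standing at 170000 nM. Compound 4 is estimated at 280000 nM, with a range from 110000 nM to 700000 nM.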

Compound 4, half-maximal cytotoxic concentration: 200000 nM
The estimate for compound 4 lay 1.4-fold (0.15 log units) above the measured number; measured number inside the range.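

In this assay, hydrogen in place of methyl gives a 1.2-fold higher number from compound 3 to compound 4 (0.07 log units; within the scatter), and set beside the earlier case the change carries over from one core to the other as far as these numbers can tell: the same change on two cores in this assay, a 2.7-fold higher number (0.44 log units; beyond the scatter) from compound 2 to compound 1 and a 1.2-fold higher number (0.07 log units; within the scatter) from compound 3 to compound 4, 2.3-fold (0.37 log units) apart, within the scatter of two such steps

Hydroxymethyl in place of hydrogen gives an 18-fold higher number from compound 2 to compound 4 (1.26 log units; beyond the scatter), and 2-hydroxyethyl in place of hydrogen gives a 6.6-fold higher number from compound 1 to compound 4 (0.82 log units; beyond the scatter), which agrees with the same change made earlier on another core: the same change on two cores in this assay, a 15-fold higher number (1.19 log units; beyond the scatter) from compound 2 to compound 3 and a 6.6-fold higher number (0.82 log units; beyond the scatter) from compound 1 to compound 4, 2.3-fold (0.37 log units) apart, within the scatter of two such steps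

Going by these compounds alone, these agreements show only that each change was consistent across two pairs of closely related compounds in a single test; they do not prove that the steps are identical, do not explain them, and do not guarantee the same result on any other core.

On these data alone, it remains open whether a longer chain would continue the large rise seen when a hydroxy-bearing chain is added. As far as these compounds go, it is equally open whether an amine or a carboxylic acid in place of the hydroxy group would give steps of similar size.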